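Swapping the pyridine group on the slowest-cleared compound

The compounds below may be only part of what the source reports. "The series", "measured", "known", "first", "only" and "open" are said of these compounds alone.

Values in an ADME assay on the whole organism (Mus musculus, strain CD-1) for pharmacokinetics; on this read-out higher numbers stand for fast clearance and lower numbers for slow clearance:
- Compound 1 `CCOc1cc([C@](O)(CCN(C)C)[C@@H](c2cc3cc(Br)ccc3nc2OC)c2ccnc(OC)c2OC)cc(OC)n1`: 9.5 mL/min/kg
- Compound 2 `COc1cc([C@](O)(CCN(C)C)[C@@H](c2cc3cc(Br)ccc3nc2OC)c2ccnc(OC)c2OC)cc(OC(C)C)n1`: 6.8 mL/min/kg
- Compound 3 `CCOc1cc([C@](O)(CCN(C)C)[C@@H](c2cc3cc(Br)ccc3nc2OC)c2ccnc(OC)c2OC)cc(OC(C)C)n1`: 3.1 mL/min/kg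

Compound 3 gives the lowest number of the three, and it stands clear of both others: a 3.1-fold lower number from compound 1 to compound 3 (0.49 log units; beyond the scatter) and a 2.2-fold lower number from compound 2 to compound 3 (0.34 log units; beyond the scatter). The remaining step, a 1.4-fold lower number from compound 1 to compound 2 (0.15 log units; within the scatter), stays within the scatter.

Compound 4 `CCOc1cc([C@](O)(CCN(C)C)[C@@H](c2cc3cc(Br)ccc3nc2OC)c2c(OC)cncc2OC)cc(OC(C)C)n1` is the next to be measured. Its change from compound 3 is a group of 10 heavy atoms (7 carbon, 1 nitrogen, 2 oxygen; one six-membered aromatic ring with 1 hetero atom) in place of a group of 10 heavy atoms (7 carbon, 1 nitrogen, 2 oxygen; one six-membered aromatic ring with 1 hetero atom), on a saturated chain carbon bound to an aromatic carbon and a saturated chain carbon. The 2,3-dimethoxypyridin-4-yl group leaves, and an isomeric group with no common name enters on a saturated chain carbon bound to an aromatic carbon and a saturated chain carbon.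

All three measured steps exchange alkyl groups on oxygen, so none of them tests this swap, and their modest sizes offer only a rough guide. No shift beyond the scatter is therefore expected in this assay, and the expected step is a 1.2-fold higher number from compound 3 to compound 4 (0.09 log units; within the scatter). For compound 4 the estimated value is 3.8 mL/min/kg, with an expected range of 1.7 mL/min/kg to 8.5 mL/min/kg.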

Compound 4, clearance: 2.7 mL/min/kg
Beside the measured number, compound 4's estimate is 1.4-fold (0.15 log units) above it; the measured number falls inside the stated range.
By their numbers in this assay, from the lowest: compounds 4 and 3 (each within the scatter of the next); then compounds 2 and 1 (each within the scatter of the next).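

Among the compounds shown here, the earlier steps all exchanged alkyl groups on oxygen, and this is the first to change the pyridine group, on a saturated chain carbon bound to an aromatic carbon and a saturated chain carbon. In this assay, replacing the 2,3-dimethoxypyridin-4-yl group with its isomer gives a step within the scatter (a 1.1-fold lower number from compound 3 to compound 4 (0.06 log units; within the scatter)), so the read-out does not separate the two arrangements, and compound 4 stands with compound 3 at the low end of the four numbers. Nothing at hand accounts for this result.

The compounds shown leave open what a pyridine group carrying an amine or a carboxylic acid in place of a methoxy group would do at this place, or a plain phenyl ring in place of the pyridine. They also leave open whether the same swap would give a similar step on compound 1 or compound 2, which carry other alkyl groups on oxygen.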